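Replacing a Chlorophenyl Group: What Is Expected of Compound 3

This account rests on a few compounds, and the source may have more. Where it says the series, first, only, none or still open, it means among the compounds named here.

Two compounds have been measured in a functional assay on OVCAR-5 cells (Homo sapiens) for antiproliferative activity, with a stated time of 48 h; a higher number here means that more compound is tolerated, a lower number that less compound is tolerated:

Compound 1 `Cc1cc(O)c(C2=NN(c3ccc(S(N)(=O)=O)cc3)C(c3ccccc3O)C2)cc1Cl`: 8120 nM
Compound 2 `Cc1cc(O)c(C2=NN(c3ccc(S(N)(=O)=O)cc3)C(c3ccccc3Cl)C2)cc1Cl`: 6230 nM

Compound 2 gives the lowest of the two numbers, and its nearest neighbour is compound 1; the step of a 1.3-fold lower number from compound 1 to compound 2 (0.12 log units; within the scatter) lies within the scatter, so the two are not separated by this assay. Compound 3 `Cc1cc(O)c(C2=NN(c3ccc(S(N)(=O)=O)cc3)C(/C=C/c3ccccc3)C2)cc1Cl` differs from compound 2 in one place: 2-phenylethenyl in place of 2-chlorophenyl on a saturated ring carbon. Within the data shown here, the only measured step, a 1.3-fold lower number from compound 1 to compound 2 (0.12 log units; within the scatter), concerns a change on an aromatic carbon and not the group on the saturated ring carbon, so no measured step bears directly on this change. With nothing in the measured pairs pointing in either direction, compound 3 is expected to stay close to compound 2 in this assay, and the estimated step of a 1.0-fold higher number from compound 2 to compound 3 (0.02 log units; within the scatter) is expected to fall within the scatter. Compound 3 is therefore estimated at 6500 nM in this assay, with a range from 2500 nM to 17000 nM.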

Compound 3, concentration lethal to 50% of the cells: 38300 nM
Beside the measured number, compound 3's estimate is 5.9-fold (0.77 log units) below it; measured number above the stated range.
By their numbers in this assay, from the lowest: compounds 2 and 1 (each within the scatter of the next); then compound 3.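

The saturated ring carbon next to the ring nitrogen turns out not to be indifferent to its group in this assay. Compound 3's 2-phenylethenyl gives a 6.1-fold higher number from compound 2 to compound 3 (0.79 log units; beyond the scatter) and, set against the 2-hydroxyphenyl group, a 4.7-fold higher number from compound 1 to compound 3 (0.67 log units; beyond the scatter), so more compound is tolerated with this group than with either of the two substituted phenyl groups, which themselves remain within the scatter of each other. Nothing available accounts for this step.

The compounds shown cannot separate the part played by the double bond outside the aromatic ring from that of the loss of the ring substituent. They also leave open how this carbon would respond to an unsubstituted phenyl, a saturated 2-phenylethyl chain or a group carrying an amine or a carboxylic acid.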